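A few compounds are considered here, and "the series" means these few. Any claim that something is new, unique, unknown or untested is made for them only; others in the source may bear on it.

Measured compounds in a functional assay on A549 cells (Homo sapiens) for antiproliferative activity, read by MTT assay, with a stated time of 48 h; a lower number here means a stronger inhibitor, a higher number a weaker inhibitor:
compound 1, `N#CC1=C(N)Oc2c(N)cc3nc4ccccc4nc3c2C12C(=O)N(Cc1cnnn1-c1cccc(C(F)(F)F)c1)c1ccccc12`: 5400 nM.
compound 2, `COc1ccc(-n2nncc2CN2C(=O)C3(C(C#N)=C(N)Oc4c(N)cc5nc6ccccc6nc5c43)c3ccccc32)cc1`: a limit of the assay, > 50000 nM.
compound 3, `N#CC1=C(N)Oc2c(N)cc3nc4ccccc4nc3c2C12C(=O)N(Cc1cnnn1-c1ccc([N+](=O)[O-])cc1)c1ccccc12`: a limit of the assay, > 50000 nM.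

Compound 3 stands at the limit of > 50000 nM in this assay, at which 2 of the 3 values shown sit, as does compound 2; compound 1 alone gives a number. Two measured steps are an at least 9.2-fold higher number from compound 1 to compound 2 (0.96 log units; beyond the scatter) and an at least 9.2-fold higher number from compound 1 to compound 3 (0.96 log units; beyond the scatter). A third is a step that the two limits leave unreadable from compound 2 to compound 3.

Compound 4, `Cc1ccc(-n2nncc2CN2C(=O)C3(C(C#N)=C(N)Oc4c(N)cc5nc6ccccc6nc5c43)c3ccccc32)cc1Cl`, differs from compound 3 as follows: 3-chloro-4-methylphenyl in place of 4-nitrophenyl on an aromatic nitrogen. Both readable steps run from 3-(trifluoromethyl)phenyl to a group absent from compound 4, so neither reads directly onto this change; they show only that the 3-(trifluoromethyl)phenyl compound gave a number where the 4-methoxyphenyl and 4-nitrophenyl compounds gave limits. Compound 4 carries neither of those two groups, and the expected step of an at least 3.3-fold lower number from compound 3 to compound 4 (0.52 log units; beyond the scatter) is therefore downward, back into the measurable range, with wide uncertainty. For compound 4 in this assay the estimate is 15000 nM, with a range from 4000 nM to 60000 nM.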

Compound 4, half-maximal inhibitory concentration: 11800 nM
Compound 4: the middle estimate sits 1.3-fold (0.10 log units) above what was measured, and the stated range covers the measured number.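

In this assay, 3-chloro-4-methylphenyl gives a second number at this position on the aromatic nitrogen, so a measurable value is not confined to 3-(trifluoromethyl)phenyl. Against the 4-nitrophenyl and 4-methoxyphenyl compounds the change reads as an at least 4.2-fold lower number from compound 3 to compound 4 (0.62 log units; beyond the scatter) and an at least 4.2-fold lower number from compound 2 to compound 4 (0.62 log units; beyond the scatter), each bounded on one side only, as compound 2 and compound 3 are limits of the assay and not numbers: the limit of > 50000 nM in this assay, at which 2 of the 4 values shown sit. Against the only other true number the change is a 2.2-fold higher number from compound 1 to compound 4 (0.34 log units; beyond the scatter), a modest step that leaves 3-(trifluoromethyl)phenyl ahead of 3-chloro-4-methylphenyl.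

The step from compound 2 to compound 3 cannot be read. Also open, as far as these compounds go, is how an unsubstituted phenyl, a 4-aminophenyl or a benzyl group would read at this position, and whether any group here gives a lower number than compound 1.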